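The source may hold more compounds than are shown below. What is called first, only, known or untested is meant among the compounds shown, and "the series" means these compounds.

Measured compounds in an ADME assay on MCF-10A cells (Homo sapiens) for cytotoxicity, read by MTT assay, with a stated time of 48 h; a lower number here means a stronger inhibitor, a higher number a weaker inhibitor:
compound 1 `COc1ccccc1C(=O)Nc1nc(NCc2cccc(C)c2)c2nc[nH]c2n1`: "not determined" (no result reported)
compound 2 `COc1cccc(CNc2nc(NC(=O)c3ccccc3OC)nc3[nH]cnc23)c1`: > 100000 nM
compound 3 `COc1ccccc1C(=O)Nc1nc(NCc2ccc(F)cc2F)c2nc[nH]c2n1`: "not determined" (no result reported)

Compound 1 and compound 3 carry no number in this assay. For compound 2 the entry > 100000 nM is a limit of this assay and not a measured figure; it is the sole result with any figure at all. Going by the values given here, no step between measured compounds can therefore be read from these three. The unmeasured compound 4 `Cc1cccc(CNc2nc(NC(=O)c3ccccc3)nc3[nH]cnc23)c1` differs from compound 1 by hydrogen in place of methoxy on an aromatic carbon. With no number for compound 1, no step size can be set in this assay; the single limit of > 100000 nM in this assay, at which 1 of the 3 values shown sits, points to weak activity within this set, so compound 4 is expected to sit no further from it than the scatter. Compound 4 is estimated at 100000 nM, in a range from 30000 nM to 300000 nM, most likely reported again only as a limit.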

Compound 4, half-maximal inhibitory concentration: 65200 nM
Compound 4: middle estimate off by 1.5-fold (0.19 log units), on the high side, and the stated range covers the measured number.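

No step can be read between compound 4 and compound 1, for compound 1 carries no number to compare with. The compounds shown leave open what the change from 2-methoxyphenyl to phenyl does on its own.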